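The compounds below may be only part of what the source reports. "The series", "measured", "known", "first", "only" and "open" are said of these compounds alone.

The series shares one core and differs only in a small group attached to an aromatic carbon of that core. Compound 1 `OCc1cc(-c2ccccc2)c2ccc(OCc3cccc(C4(O)CCOCC4)c3)cc2c1` carries hydroxymethyl there and in a functional assay for inhibition, with Homo sapiens as the target (on this read-out higher numbers stand for weaker inhibition and lower numbers for stronger inhibition), compound 1 gives 9 nM. Compound 2 `COCc1cc(-c2ccccc2)c2ccc(OCc3cccc(C4(O)CCOCC4)c3)cc2c1` carries methoxymethyl and in this assay compound 2 gives 4 nM, the lowest of the three numbers measured. Compound 3 `COC(C)c1cc(-c2ccccc2)c2ccc(OCc3cccc(C4(O)CCOCC4)c3)cc2c1` carries 1-methoxyethyl and in this assay compound 3 gives 41 nM. The steps show that this position answers to small changes: a 2.3-fold lower number from compound 1 to compound 2 (0.35 log units; beyond the scatter), while a 10-fold higher number from compound 2 to compound 3 (1.01 log units; beyond the scatter) and a 4.6-fold higher number from compound 1 to compound 3 (0.66 log units; beyond the scatter).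

Compound 4 `Cn1nnnc1-c1cc(-c2ccccc2)c2ccc(OCc3cccc(C4(O)CCOCC4)c3)cc2c1` has not yet been measured. Relative to compound 2 it changes as follows: 1-methyl-1H-tetrazol-5-yl in place of methoxymethyl on an aromatic carbon. Within the data shown here, no measured step replaces a chain by a ring here, so none bears on this change directly; the nearest guide is that adding a single methyl on the chain carbon gave the large step from compound 2 to compound 3. A change that swaps the whole methoxymethyl for a five-membered aromatic ring is larger still, so the number for compound 4 in this assay is expected to rise beyond the scatter, though by how much is uncertain. The estimated step is a 5.0-fold higher number from compound 2 to compound 4 (0.70 log units; beyond the scatter). For compound 4 the estimate in this assay is 20 nM, with a range from 5 nM to 80 nM.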

Compound 4, half-maximal inhibitory concentration: > 67 nM
Compound 4 was reported as a limit; the forecaster's own chance of this, stated with the estimate: 3%; middle value at least 3.3-fold (0.52 log units) away from the limit.
By their numbers in this assay, from the lowest: compound 2; then compound 1; then compound 3. At a limit, above all of these: compound 4.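

Compound 4 is reported in this assay only as a limit and not as a number: the limit of > 67 nM in this assay, at which 1 of the 4 values shown sits. The earlier compounds shown here varied only a short chain at this position, whereas replacing that chain with the 1-methyl-1H-tetrazol-5-yl ring gives an at least 16-fold higher number from compound 2 to compound 4 (1.22 log units; beyond the scatter) and an at least 7.4-fold higher number from compound 1 to compound 4 (0.87 log units; beyond the scatter), so this ring does not preserve the low numbers seen with methoxymethyl and hydroxymethyl. Against 1-methoxyethyl the reading is less firm, with an at least 1.6-fold higher number from compound 3 to compound 4 (0.21 log units; that floor lies within the scatter), so the limit alone does not clearly set this ring apart from that branched chain.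

The compounds shown leave open how far above the limit the true number lies, and whether the rise belongs to this tetrazole in particular or would come with any ring on this aromatic carbon. An oxazole, a pyridine or a carboxylic acid in the same place would help to separate those readings and show whether the position can accept anything other than a short chain.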